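A few compounds are considered here, and "the series" means these few. Any claim that something is new, unique, unknown or untested is made for them only; others in the source may bear on it.

Three analogues on the shared core of compound 1 `CCCCOCCOC1CCN(c2nc(N)c3cc(OC)c(OC)cc3n2)CC1` have been run in an assay on brain for displacement of a labelled ligand from Adrenergic receptor alpha-1 (Rattus norvegicus); on this read-out lower numbers stand for stronger inhibition and higher numbers for weaker inhibition. Compound 1 gives 1.03 nM in this assay. Compound 2 `COc1cc2nc(N3CCC(OCC(C)O)CC3)nc(N)c2cc1OC` gives 3.52 nM, and compound 3 `COc1cc2nc(N3CCC(OCC(C)(C)O)CC3)nc(N)c2cc1OC` gives 1.28 nM. Among these three numbers compound 3 stands second highest; its nearest neighbour is compound 1, and the two are within the scatter of each other, while compound 2 stands beyond the scatter from it. The step of a 2.8-fold lower number from compound 2 to compound 3 (0.44 log units; beyond the scatter) is modest, and so is a 3.4-fold higher number from compound 1 to compound 2 (0.53 log units; beyond the scatter), whereas a 1.2-fold higher number from compound 1 to compound 3 (0.09 log units; within the scatter) is within the scatter.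

Compound 4 `CCOCC(OC1CCN(c2nc(N)c3cc(OC)c(OC)cc3n2)CC1)c1ccccc1` is not yet measured. It differs from compound 3 by 2-ethoxy-1-phenylethyl in place of 2-hydroxy-2-methylpropyl on an oxygen on a saturated carbon. Among the measured compounds shown here, no step among the measured compounds exchanges a hydroxyl-bearing side chain for a larger ether that carries a ring, so the bearing of the measured steps is indirect. The step of a 1.2-fold higher number from compound 1 to compound 3 (0.09 log units; within the scatter) shows that a side chain holding an ether and no hydroxyl and one holding a hydroxyl and no ether sit within the scatter of each other, so the loss of the donor on going to compound 4 is expected to matter little on its own. For compound 4 the step of a 1.3-fold lower number from compound 3 to compound 4 (0.11 log units; within the scatter) is therefore expected to stay within the scatter. Compound 4 is estimated at 1 nM, with a range from 0.3 nM to 3.5 nM.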

Compound 4, inhibition constant: 10 nM
For compound 4 the middle estimate is 10-fold (1.00 log units) below the measured one, and the stated range ends below it.
By their numbers in this assay, from the lowest: compounds 1 and 3 (each within the scatter of the next); then compound 2; then compound 4.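

On an oxygen on a saturated carbon, the side chain is not as tolerant in this assay as the first three compounds suggested: with 2-ethoxy-1-phenylethyl there is a 7.8-fold higher number from compound 3 to compound 4 (0.89 log units; beyond the scatter), along with a 2.8-fold higher number from compound 2 to compound 4 (0.45 log units; beyond the scatter) and a 9.7-fold higher number from compound 1 to compound 4 (0.99 log units; beyond the scatter), which places compound 4 as the weakest of the four. The absence of a hydroxyl does not by itself go with this shift, as 2-butoxyethyl in compound 1 also lacks one and stays within the scatter of the 2-hydroxy-2-methylpropyl of compound 3, so the change now points to what 2-ethoxy-1-phenylethyl adds, namely its six-membered aromatic ring and its larger heavy-atom count. No measurement here explains why the number rises at this position.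

The compounds shown leave open whether the higher number goes with the phenyl ring itself or with the larger chain as a whole, since compound 4 changes both together, and a 2-ethoxyethyl side chain compared with compound 4 would separate them. Also open, on these data alone, is how this assay responds to an amine or a carboxylic acid at the end of the side chain.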